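Swapping the aryl group beside the pyridine-type nitrogen

This account rests on a few compounds, and the source may have more. Where it says the series, first, only, none or still open, it means among the compounds named here.

Of the compounds shown here, three sharing one core have been measured in an assay on isolated protein for inhibition of DNA topoisomerase 1 (Homo sapiens), tested at 100 uM; a lower number here means a weaker effect, a higher number a stronger effect of the compound at the concentration tested. Compound 1 `Clc1ccc(-c2cc(-c3ccsc3)nc(-c3ccco3)c2)o1` gives 8.2%, compound 2 `Cc1cccc(-c2cc(-c3ccc(Cl)o3)cc(-c3ccsc3)n2)c1` gives 7.5%, and compound 3 `Clc1ccc(-c2cc(-c3cccs3)nc(-c3ccccc3Cl)c2)o1` gives 41.3%. Compound 2 therefore stands at the low end of the three numbers, with compound 1 inside the scatter of it, while compound 3 lies well above both. Going by the values given here, the only single-point step among them, a number 0.7 percentage points lower from compound 1 to compound 2 (within the scatter), is within the scatter.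

Compound 4 `Clc1ccc(-c2cc(-c3ccc(Cl)o3)cc(-c3ccsc3)n2)cc1` differs from compound 2 by 4-chlorophenyl in place of 3-methylphenyl on an aromatic carbon. The step from compound 1 to compound 2 bears on this change, since it also exchanges the group on that same carbon, and it was within the scatter. Among the compounds with values here, compound 3, though higher in this assay, differs from compound 2 in two places, so its number gives no single step to lean on. The author therefore expects only a small step in this assay, a number 4.5 percentage points higher from compound 2 to compound 4 (within the scatter), from compound 2 to compound 4, with no direction beyond the scatter. The estimate for compound 4 is 12%, within a range from 3% to 30%.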

Compound 4, a percentage reported as inhibition, at one concentration (the size of the read-out at that concentration, not a potency): 29.8%
For compound 4 the middle estimate is 17.8 percentage points below the measured one; measured number inside the range.
By their numbers in this assay, from the lowest: compounds 2 and 1 (each within the scatter of the next); then compound 4; then compound 3.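

The position next to the ring nitrogen does respond in this assay: the earlier step between furan-2-yl and 3-methylphenyl stayed within the scatter, whereas 4-chlorophenyl brings a number 22.3 percentage points higher from compound 2 to compound 4 (beyond the scatter) and a number 21.6 percentage points higher from compound 1 to compound 4 (beyond the scatter). Both steps lie beyond the scatter, so an aryl group at this carbon is not interchangeable with any other, even though 3-methylphenyl and 4-chlorophenyl have the same count of heavy atoms. Nothing shown here offers an explanation for the rise.

The step changes both the substituent and its place on the phenyl ring, so these compounds cannot separate the contribution of the chlorine from that of its location. On these data alone, how an amine or a carboxylic acid on that phenyl ring would read in this assay also remains open.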